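A few compounds are considered here, and "the series" means these few. Any claim that something is new, unique, unknown or untested is made for them only; others in the source may bear on it.

Compound 1 `c1ccc(COc2ccc(OCCOCCOC3CCCC3)cc2)cc1`: > 100000 nM
Compound 2 `Clc1ccc(COc2ccc(OCCOCCNC3CCCCC3)cc2)cc1`: 2650 nM
Compound 3 `COC(=O)c1ccc(COc2ccc(OCCOCCNC3CCCC3)cc2)cc1`: 6990 nM

In a functional assay on SK-OV-3 cells (Homo sapiens) for inhibition, read by CCK-8 assay, with a stated time of 70 h (a lower number here means a stronger inhibitor, a higher number a weaker inhibitor), compound 1 gives only a limit, > 100000 nM, and no number is known for it; it stands at the limit of > 100000 nM in this assay, at which 1 of the 3 values shown sits. Compound 2 gives 2650 nM in this assay, and compound 3 gives 6990 nM there, both as numbers. Compound 4 `c1ccc(COc2ccc(OCCOCCNC3CCCCCC3)cc2)cc1` has not yet been measured. It differs from compound 1 by cycloheptylamino in place of cyclopentyloxy on a saturated chain carbon, two bonds along the chain from an oxygen on a saturated carbon. Compound 2 and compound 3 both carry an amino ring at that position of the chain and both give numbers, while compound 1 with its cyclopentyloxy group gives only a limit. The author therefore expects the step of an at least 25-fold lower number from compound 1 to compound 4 (1.39 log units; beyond the scatter) to be large and toward stronger inhibition. For compound 4 the estimate in this assay is 4000 nM, within a range from 1500 nM to 12000 nM.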

Compound 4, half-maximal inhibitory concentration: 7460 nM
Beside the measured number, compound 4's estimate is 1.9-fold (0.27 log units) below it; low and high end bracket the measured number.
By their numbers in this assay, from the lowest: compound 2; then compounds 3 and 4 (each within the scatter of the next). At a limit, above all of these: compound 1.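

In this assay, replacing cyclopentyloxy with cycloheptylamino on an otherwise unchanged core gives an at least 13-fold lower number from compound 1 to compound 4 (1.12 log units; beyond the scatter). For the compounds shown here, this is the first comparison to isolate a change at this position, as the earlier compounds differ from one another in more than one place. The full size of the step stays unknown because compound 1 gives only a limit: the limit of > 100000 nM in this assay, at which 1 of the 4 values shown sits.

The change alters the ring and the linking atom together, so their contributions remain unseparated. A cycloheptyloxy group on the same core would show whether the ring alone carries the step.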